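This account rests on a few compounds, and the source may have more. Where it says the series, first, only, none or still open, it means among the compounds named here.

Three compounds built on one shared core were measured in a functional assay on A549 cells (Homo sapiens) for antiproliferative activity, read by MTT assay, with a stated time of 72 h; on this read-out lower numbers stand for stronger inhibition and higher numbers for weaker inhibition. Compound 1 `C=C(Cl)C(=O)Nc1cc(Nc2nccc(-c3cn(C)c4ccccc34)n2)c(OC)cc1N(C)CCN(C)C` gives 7520 nM in this assay. Compound 3 `C/C=C\C(=O)Nc1cc(Nc2nccc(-c3cn(C)c4ccccc34)n2)c(OC)cc1N(C)CCN(C)C` gives 660 nM in this assay. Compound 2 `COc1cc(N(C)CCN(C)C)c(NC(=O)C(Cl)=C(Cl)Cl)cc1Nc1nccc(-c2cn(C)c3ccccc23)n1` reaches only a limit of the assay, > 50000 nM, in this assay. Compound 2 thus stands at the weak end of the set, at the limit of > 50000 nM in this assay, at which 1 of the 3 values shown sits. Compound 4 `COc1cc(N(C)CCN(C)C)c(NC(=O)/C=C\C(C)C)cc1Nc1nccc(-c2cn(C)c3ccccc23)n1` differs from compound 2 in one place: 3-methylbut-1-en-1-yl in place of 1,2,2-trichloroethenyl on a carbonyl carbon. The closest measured comparison is an at least 75-fold lower number from compound 2 to compound 3 (1.87 log units; beyond the scatter), and an 11-fold lower number from compound 1 to compound 3 (1.06 log units; beyond the scatter) points the same way, both with an alkenyl group entering on the carbonyl carbon. A large downward step is therefore expected for compound 4, an at least 33-fold lower number from compound 2 to compound 4 (1.52 log units; beyond the scatter). Compound 4 is estimated at 1500 nM, within a range of 400 nM to 6000 nM.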

Compound 4, half-maximal inhibitory concentration: 612 nM
For compound 4 the middle estimate is 2.5-fold (0.39 log units) above the measured one; low and high end bracket the measured number.
By their numbers in this assay, from the lowest: compounds 4 and 3 (each within the scatter of the next); then compound 1. At a limit, above all of these: compound 2.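

On the carbonyl carbon, 3-methylbut-1-en-1-yl has the same heavy-atom count as 1,2,2-trichloroethenyl, yet the exchange gives an at least 81-fold lower number from compound 2 to compound 4 (1.91 log units; beyond the scatter). Against the 1-chloroethenyl group the same alkenyl group gives a 12-fold lower number from compound 1 to compound 4 (1.09 log units; beyond the scatter), while isopropyl in place of methyl on a double-bonded chain carbon leaves a 1.1-fold lower number from compound 3 to compound 4 (0.03 log units; within the scatter). Compound 2 stands only at a limit, so its step is a bound: the limit of > 50000 nM in this assay, at which 1 of the 4 values shown sits.

Going by these compounds, what stays open is whether a longer chain, an amine or a carboxylic acid in place of that isopropyl would hold this level.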